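Dropping the Dimethylamino Group: Expectation for Compound 3

This account rests on a few compounds, and the source may have more. Where it says the series, first, only, none or still open, it means among the compounds named here.

Measured so far in a functional assay on SMMC-7721 cells (Homo sapiens) for cytotoxicity, read by MTT assay, with a stated time of 72 h; a lower number here means a stronger inhibitor, a higher number a weaker inhibitor:
compound 1, `CN(C)c1ccc(C=C2C(=O)N(c3ccc(Cl)cc3)N(c3ccc(Cl)cc3)C2=O)cc1`, > 128000 nM
compound 2, `O=C1C(=Cc2ccco2)C(=O)N(c2ccc(Cl)cc2)N1c1ccc(Cl)cc1`, 19500 nM

Compound 1 reaches only a limit of this assay, (the limit of > 128000 nM in this assay, at which 1 of the 2 values shown sits), so its true value is not known as a number. Compound 2 sits well inside the measured range. Among the measured compounds shown here, the step of an at least 6.5-fold lower number from compound 1 to compound 2 (0.81 log units; beyond the scatter) is the only measured step that bears on the question here.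

Compound 3, `O=C1C(=Cc2ccccc2)C(=O)N(c2ccc(Cl)cc2)N1c1ccc(Cl)cc1`, differs from compound 1 by hydrogen in place of dimethylamino on an aromatic carbon. For the measured compounds named here, the change is smaller than the one from compound 1 to compound 2, yet it removes the same 4-(dimethylamino)phenyl feature at the same place, so a lower number in this assay than the limit of compound 1 is expected, in the same direction as an at least 6.5-fold lower number from compound 1 to compound 2 (0.81 log units; beyond the scatter) and of roughly comparable size. For compound 3 the estimated step is an at least 4.2-fold lower number from compound 1 to compound 3 (0.63 log units; beyond the scatter), and its expected value is 30000 nM, between 10000 nM and 100000 nM.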

Compound 3, half-maximal inhibitory concentration: 26200 nM
Compound 3: the middle estimate sits 1.1-fold (0.06 log units) above what was measured; low and high end bracket the measured number.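

In this assay, taking away the dimethylamino group alone and keeping the phenyl ring gives an at least 4.8-fold lower number from compound 1 to compound 3 (0.68 log units; beyond the scatter), so a change at this single aromatic carbon is enough for a step beyond the scatter, with no change of the ring itself. As far as these compounds go, compound 1 stands only at a limit, so the true size of this step remains unknown: the limit of > 128000 nM in this assay, at which 1 of the 3 values shown sits. The new compound also shows that, on the double-bonded chain carbon, phenyl and furan-2-yl are not told apart here: a 1.3-fold higher number from compound 2 to compound 3 (0.13 log units; within the scatter).

Whether any group at this aromatic carbon would give a number like that of compound 1, or only dimethylamino, remains open, since neither a primary amine nor a carboxylic acid stands there in the compounds shown. From the compounds shown here alone, how a saturated ring such as piperidine would behave on the chain carbon also remains open.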